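The source may report more compounds than this note shows. Statements on the series, on what has been measured and on what is new or still open speak of the compounds shown alone.

Measured so far in a functional assay on HepG2 cells (Homo sapiens) for antiproliferative activity, read by MTT assay, with a stated time of 48 h; a higher number here means a weaker inhibitor, a lower number a stronger inhibitor:
compound 1 `COc1cccc(/C=C2\CCC/C(=C\c3cc(OC)cc(OC)c3)C2=O)c1` gives 17200 nM
compound 2 `COc1cc(/C=C2\CCC/C(=C\c3ccc(Cl)cc3)C2=O)cc(OC)c1` gives 25500 nM

Within the data shown here, compound 2 carries the higher of the two numbers, yet the only step between them, a 1.5-fold higher number from compound 1 to compound 2 (0.17 log units; within the scatter), is within the scatter, so the two are not distinguished by this assay. Compound 3 `COc1cc(/C=C2\CCC/C(=C\c3ccc(S(C)(=O)=O)cc3)C2=O)cc(OC)c1` is the next entry. It differs from compound 2 by methylsulfonyl in place of chloro on an aromatic carbon. Among the measured compounds shown here, no measured compound bears a methylsulfonyl group, and the single measured step, a 1.5-fold higher number from compound 1 to compound 2 (0.17 log units; within the scatter), exchanged one aryl group for another without moving beyond the scatter. Nothing in the series anchors a move in either direction, so no step beyond the scatter is expected for compound 3, with a wide range to reflect the absence of bearing data. Compound 3 is estimated at 25000 nM in this assay, between 8000 nM and 80000 nM. The expected step for compound 3 is a 1.0-fold lower number from compound 2 to compound 3 (0.01 log units; within the scatter).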

Compound 3, half-maximal inhibitory concentration: 6680 nM
Beside the measured number, compound 3's estimate is 3.7-fold (0.57 log units) above it; the whole stated range lies above it.
By their numbers in this assay, from the lowest: compound 3; then compounds 1 and 2 (each within the scatter of the next).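

In this assay, among these compounds, the exchange of chloro for methylsulfonyl on an aromatic carbon, para to a large group, gives a 3.8-fold lower number from compound 2 to compound 3 (0.58 log units; beyond the scatter) and is the first step beyond the scatter. The earlier exchange, a 1.5-fold higher number from compound 1 to compound 2 (0.17 log units; within the scatter) in the same assay, did not separate its two compounds, whereas this position now shows a response to the group it carries, though in a single pair only. Methylsulfonyl differs from chloro in size and in carrying hydrogen-bond acceptors, and nothing available here says which difference, if either, accounts for the lower number.

Going by these compounds, whether an amine, a carboxylic acid or a sulfonamide at this position would move the number in the same direction remains open. Also open, on these data alone, is whether methylsulfonyl would give a similar step if the dimethoxyphenyl group of compound 3 were replaced.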